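The compounds below may be only part of what the source reports. "The series", "measured", "known", "first", "only" and "open" are said of these compounds alone.

In a functional assay on PANC-1 cells (Homo sapiens) for antiproliferative activity, read by sulforhodamine B assay, with a stated time of 48 h (on this read-out lower numbers stand for stronger inhibition of growth and higher numbers for weaker inhibition of growth), compound 1 (`O=[N+]([O-])c1ccc(-c2nnc(C3=C(Cl)c4ccccc4CCC3)o2)cc1`) gives 3980 nM and compound 2 (`Cc1cc2c(cc1C)C(Cl)=C(c1nnc(-c3ccccc3)o1)CCC2`) gives 4120 nM, so compound 2 stands level with compound 1 within the scatter. Compound 3 (`Cc1cc2c(cc1C)C(Cl)=C(c1nnc(-c3cccc(I)c3)o1)CCC2`) carries one change from compound 2: iodo in place of hydrogen on an aromatic carbon, with iodo in place of hydrogen on an aromatic carbon. Among the measured compounds shown here, no measured pair shows this change, so little guidance exists. The expected move is a 1.3-fold lower number from compound 2 to compound 3 (0.11 log units; within the scatter), a small one that stays within the scatter, if anything toward stronger inhibition. For compound 3 the estimated value is 3200 nM, with an expected range from 1100 nM to 9000 nM.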

Compound 3, concentration for 50% growth inhibition: 4120 nM
Compound 3: the middle estimate sits 1.3-fold (0.11 log units) below what was measured; low and high end bracket the measured number.
By their numbers in this assay, from the lowest: compounds 1, 2 and 3 (each within the scatter of the next).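

Phenyl to 3-iodophenyl brings no change at the digits printed from compound 2 to compound 3 (within the scatter) in this assay, so on this aromatic carbon a single iodine atom in place of hydrogen leaves growth inhibition without a readable shift. Among the compounds shown here, the earlier compounds offered no pair differing in one place, so this is the first single change that can be read. No measurement shown gives a reason for this result.

As far as these compounds go, whether an amine, a carboxylic acid or a methoxy group on the same carbon would also leave the value level remains open. So does the outcome of iodo on other carbons of that ring.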